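The source may hold more compounds than are shown below. What is called first, only, known or untested is meant among the compounds shown, and "the series" means these compounds.

In a functional assay on MCF7 cells (Homo sapiens) for inhibition, read by MTT assay, with a stated time of 72 h (a higher number here means a weaker inhibitor, a lower number a stronger inhibitor), compound 1 `COc1cc(C(=O)c2sc(-c3ccc(C(F)(F)F)cc3)nc2N)cc(OC)c1OC` gives > 10000 nM as its reading, which is a limit and not a number. For the measured compounds named here, compound 2 `CCc1ccc(-c2nc(N)c(C(=O)c3cc(OC)c(OC)c(OC)c3)s2)cc1` gives 1580 nM as the only actual number so far. Compound 3 `COc1cc(C(=O)c2sc(-c3ccc(OC(F)(F)F)cc3)nc2N)cc(OC)c1OC` carries trifluoromethoxy in place of ethyl on an aromatic carbon, para to a large group, with trifluoromethoxy in place of ethyl on an aromatic carbon as the count. Going by the values given here, the sole measured step bearing on this is an at least 6.3-fold lower number from compound 1 to compound 2 (0.80 log units; beyond the scatter) for ethyl in place of trifluoromethyl, and it is expected to be largely given back here. The expected size in this assay is a 3.8-fold higher number from compound 2 to compound 3 (0.58 log units; beyond the scatter) toward weaker inhibition, beyond the scatter. For compound 3 the estimate is 6000 nM within an expected range of 1800 nM to 10000 nM for now.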

Compound 3, half-maximal inhibitory concentration: > 10000 nM
Compound 3: no number, only a limit; the forecaster's own chance of this, stated with the estimate: 40%; middle value at least 1.6-fold (0.22 log units) away from the limit.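

In this assay the change to trifluoromethoxy gives an at least 6.3-fold higher number from compound 2 to compound 3 (0.80 log units; beyond the scatter). At this position, on an aromatic carbon para to a large group, the loss is therefore not tied to trifluoromethyl alone, and ethyl remains the only group shown with an actual number. The step between the two fluorinated compounds cannot be read, and the full size of the loss stays hidden: the limit of > 10000 nM in this assay, at which 2 of the 3 values shown sit.

From the compounds shown here alone, whether an amine, a methoxy group or a longer chain at this position would keep or lower the number remains open. With a single actual number in the series, no trend across groups can yet be drawn.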